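One Added Methyl on an Already Stable Compound

The source may report more compounds than this note shows. Statements on the series, on what has been measured and on what is new or still open speak of the compounds shown alone.

In an ADME assay on microsomes from liver (Homo sapiens) for metabolic stability, with a stated time of 30 min (on this read-out higher numbers stand for a more stable compound and lower numbers for a less stable compound), compound 1 `COc1nc2c(cc1Cc1cccc(Cl)c1F)c(=O)c(C(=O)O)cn2[C@H](CO)C(C)(C)C` gives 82% and compound 2 `COc1nc2c(cc1NCc1c(F)cc(F)cc1F)c(=O)c(C(=O)O)cn2[C@H](CO)C(C)C` gives 82% so compound 2 stands level with compound 1 at the digits shown. Compound 3 `COc1nc2c(cc1NCc1c(F)cc(F)cc1F)c(=O)c(C(=O)O)cn2[C@H](CO)C(C)(C)C` differs from compound 2 by a single change methyl in place of hydrogen on a saturated chain carbon bound to three saturated chain carbons in which methyl takes the place of hydrogen on a saturated chain carbon bound to three saturated chain carbons. The same difference reads as isopropyl to tert-butyl. For the measured compounds named here, no pair of measured compounds isolates this change, so the data give no direct size for it. Compound 1 carries the 1-(hydroxymethyl)-2,2-dimethylpropyl chain and gives 82% in this assay and this supports the expectation of no step beyond the scatter, in either direction. The expected outcome is no change at the digits printed from compound 2 to compound 3 (within the scatter) and no more. The estimate for compound 3 is 82% with 70% to 93% as the expected range.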

Compound 3, percent of the compound remaining: 75%
Estimate against measurement, compound 3: 7 percentage points above, within the range that was stated.
By their numbers in this assay, from the lowest: compounds 3, 1 and 2 (each within the scatter of the next).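

In this assay, methyl in place of hydrogen on a saturated chain carbon bound to three saturated chain carbons, the change from isopropyl to tert-butyl, now has a measured size: a number 7 percentage points lower from compound 2 to compound 3 (within the scatter) and so stays inside the usual scatter. With the 1-(hydroxymethyl)-2,2-dimethylpropyl chain held constant, (2,4,6-trifluorobenzyl)amino in place of 3-chloro-2-fluorobenzyl on an aromatic carbon gives a number 7 percentage points lower from compound 1 to compound 3 (within the scatter) and likewise stays inside the scatter. Nothing at hand speaks to what lies behind either step.

The compounds shown leave open how this read-out responds when a cyclopropyl or phenyl group stands in place of the tert-butyl. They also leave open what happens when a carboxylic acid or an amine replaces the hydroxymethyl on the same chain.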